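Chloro for methyl beside the sulfoamino nitrogen

A few compounds are considered here, and "the series" means these few. Any claim that something is new, unique, unknown or untested is made for them only; others in the source may bear on it.

Compound 1 `Cc1cc(-c2nc3ccccc3s2)ccc1N` gives 2.51 in a physicochemical assay for lipophilicity, at pH 7.4; a lower number here means a more polar compound, a higher number a more lipophilic compound. Compound 2 `Nc1ccc(-c2nc3ccccc3s2)cc1Cl` gives in this assay only a limit, > 3.2. The change chloro in place of methyl on an aromatic carbon makes a step of a number at least 0.69 log units higher from compound 1 to compound 2 (beyond the scatter), which rests on (the limit of > 3.2 in this assay, at which 1 of the 3 values shown sits). Compound 3 `Cc1cc(-c2nc3ccccc3s2)ccc1NS(=O)(=O)O` gives in this assay likewise only a limit, < 3. That leaves the step that the limit leaves unreadable from compound 1 to compound 3, fixed only by the limit of < 3 in this assay, at which 1 of the 3 values shown sits. The cores of the two pairs differ by sulfo in place of hydrogen on a nitrogen on an aromatic ring. Compound 4 `O=S(=O)(O)Nc1ccc(-c2nc3ccccc3s2)cc1Cl` carries the same kind of change as compound 2: chloro in place of methyl on an aromatic carbon. The place is not identical: here the chloro stands ortho to a sulfoamino group (5 heavy atoms), in compound 2 ortho to an amino group (1 heavy atom). Compound 4 is expected in this assay at 2, between 1 and 3. The expected step that the limit leaves unreadable from compound 3 to compound 4 is taken from a number at least 0.69 log units higher from compound 1 to compound 2 (beyond the scatter) for the same kind of change. The starting point of compound 3 is itself only a limit, so the estimate is loose.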

Compound 4, distribution coefficient: < 2.19
Compound 4 gave a limit, no number (the forecaster's own chance of this, stated with the estimate: 40%); the middle value is on the limit's open side.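

In this assay compound 4 gives only a limit, < 2.19. The steps from compound 1 to compound 3 and from compound 3 to compound 4 cannot be read, so the change of chloro in place of methyl has no size on the sulfoamino core to set against its size on the amino core, and carry-over between the cores is neither shown nor ruled out. What can be read is that sulfo in place of hydrogen on the nitrogen, with chloro kept, gives a number at least 1.01 log units lower from compound 2 to compound 4 (beyond the scatter).

On these data alone, whether compound 3 and compound 4 differ in this assay stays open. Also open, as far as these compounds go, is how the chloro for methyl change would read with an acetyl group or a carboxylic acid in place of the sulfo group.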